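A few compounds are considered here, and "the series" means these few. Any claim that something is new, unique, unknown or untested is made for them only; others in the source may bear on it.

Of the compounds shown here, three built on one shared core have so far been tested in a functional assay on CHO cells for antagonist activity at prostaglandin E2 receptor EP3 subtype (Homo sapiens), read by cAMP accumulation, with a stated time of 30 min; on this read-out higher numbers stand for weaker inhibition and lower numbers for stronger inhibition. Compound 1, `CCC(CC)C(/C=C1\OC(=O)NC1=O)c1ccc(-c2ccc3cccc(F)c3c2)[nH]c1=O`, gives 23 nM in this assay. Compound 2, `CC(C)[C@@H](c1ccc(-c2ccc3cccc(F)c3c2)[nH]c1=O)[C@H]1OC(=O)NC1=O`, gives 92 nM, and compound 3, `CC(C)C(c1ccc(-c2ccc3cccc(F)c3c2)[nH]c1=O)C1C(=O)NC(=O)N1C`, gives 320 nM. Compound 1 therefore has the lowest number of the three, meaning the strongest inhibition: compound 2 stands nearest to it, and even that gap lies beyond the usual scatter, while compound 3 stands furthest away. Compound 2 and compound 3 each differ from compound 1 in more than one place, so none of these gaps can be pinned on a single change.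

The compound still to be measured is compound 4, `O=C1NC(=O)/C(=C/C(c2ccccc2)c2ccc(-c3ccc4cccc(F)c4c3)[nH]c2=O)O1`. It differs from compound 1 in exactly one place: phenyl in place of pentan-3-yl on a saturated chain carbon bound to an aromatic carbon and a double-bonded chain carbon. Going by the values given here, no pair of measured compounds shows what this exchange of pentan-3-yl for phenyl does on its own, so the expectation rests on the structural change alone. The step from compound 1 to compound 4 is expected to be a 1.5-fold higher number from compound 1 to compound 4 (0.18 log units; within the scatter), a slight weakening that may well lie within the scatter. Compound 4 is accordingly estimated at 35 nM in this assay, with a plausible range from 9 nM to 140 nM.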

Compound 4, half-maximal inhibitory concentration: 190 nM
Beside the measured number, compound 4's estimate is 5.4-fold (0.73 log units) below it, and the stated range ends below it.
By their numbers in this assay, from the lowest: compound 1; then compound 2; then compounds 4 and 3 (each within the scatter of the next).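

In this assay, going by these compounds alone, the saturated chain carbon bound to an aromatic carbon and a double-bonded chain carbon proves sensitive to the group it carries: with an 8.3-fold higher number from compound 1 to compound 4 (0.92 log units; beyond the scatter), this is the first step here that can be tied to a single change. On this core, pentan-3-yl and phenyl are therefore not interchangeable, even though both contain only carbon and neither carries a net charge, and phenyl gives the weaker inhibition. Nothing available explains why this exchange weakens inhibition.

Going by these compounds, it remains open whether the loss comes with any ring at this position or only with phenyl: cyclohexyl, a six-membered carbon ring that is not aromatic, would help separate those two readings, while a shorter chain such as ethyl would show how much of the pentan-3-yl group is needed. A single step also cannot show whether the same exchange would have a similar effect on the other compounds built on this core.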